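The compounds below may be only part of what the source reports. "The series", "measured", "known", "first", "only" and "open" are said of these compounds alone.

Four compounds share one core, differing in the chain on one nitrogen and, in the last case, in the benzyl group. Compound 1 `CCCCn1c(=O)[nH]c(=O)c2[nH]c(-c3cnn(Cc4ccccc4)c3)nc21` carries a butyl chain, and in an assay on CHO cells for displacement of a labelled ligand from adenosine receptor A1 (Homo sapiens) (on this read-out lower numbers stand for stronger inhibition and higher numbers for weaker inhibition), compound 1 gives "not determined" (no result reported). Compound 2 `CC(C)Cn1c(=O)[nH]c(=O)c2[nH]c(-c3cnn(Cc4ccccc4)c3)nc21` carries an isobutyl chain, and in this assay compound 2 gives "not determined" (no result reported). Compound 3 `CCCn1c(=O)[nH]c2nc(-c3cnn(Cc4ccccc4)c3)[nH]c2c1=O` carries a propyl chain, and in this assay compound 3 gives 1600 nM. That is the only numerical result among the three measured compounds, so nothing within the series can be set against it, and it cannot be called strong or weak by comparison.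

Compound 4 `CCCn1c(=O)[nH]c2nc(-c3cnn(Cc4cccc(F)c4)c3)[nH]c2c1=O` keeps the core and the propyl chain of compound 3 and differs in one place: fluoro in place of hydrogen on an aromatic carbon. For the measured compounds named here, no pair of measured compounds differs in a single place, so no measured step shows how a change of this kind has behaved here. The change is small in extent, and with nothing in the data pointing either way, the step in this assay is expected to stay within the usual scatter, with no clear direction. The expected step is a 1.1-fold lower number from compound 3 to compound 4 (0.06 log units; within the scatter). Compound 4 is therefore expected to give about 1400 nM in this assay, most likely between 500 nM and 4000 nM.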

Compound 4, inhibition constant: 1800 nM
For compound 4 the middle estimate is 1.3-fold (0.11 log units) below the measured one, within the range that was stated.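

Fluoro in place of hydrogen gives the series its first readable step: in this assay, the result is a 1.1-fold higher number from compound 3 to compound 4 (0.05 log units; within the scatter), and this lies within the scatter. Compound 3 and compound 4 therefore cannot be told apart on this read-out. For this one position, the aromatic carbon meta to a large group, turning benzyl into 3-fluorobenzyl leaves no difference that can be read, and nothing measured here speaks to the reason for this result.

A single fluoro says little about what other groups would do at this carbon, so a methoxy, a trifluoromethyl, an amine or a carboxylic acid on the same ring could behave quite differently, and a result for any of them would show whether this position stays as undemanding with a larger or charged group in place. Going by these compounds, the chain on the nitrogen also stays open, since propyl is the only chain here with a number, which leaves the effect of a longer chain such as pentyl, or of a shorter one such as ethyl, unknown.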